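This account rests on a few compounds, and the source may have more. Where it says the series, first, only, none or still open, it means among the compounds named here.

Measured so far in a functional assay on A2780 cells (Homo sapiens) for cytotoxicity, read by MTT assay, with a stated time of 24 h; on this read-out higher numbers stand for weaker inhibition and lower numbers for stronger inhibition:
- compound 1, `CCCCC[C@@H](CCC[C@H]1CC=CC(=O)O1)OC`: 20600 nM
- compound 2, `CCCCC[C@H](C[C@@H](O)C[C@@H]1CC=CC(=O)O1)OC`: 54500 nM
- compound 3, `CCCCC[C@@H](C[C@@H](O)C[C@H]1CC=CC(=O)O1)OC`: 33700 nM

Compound 1 stands lowest of the three numbers in this assay. Its nearest neighbour is compound 3, the step being a 1.6-fold higher number from compound 1 to compound 3 (0.21 log units; within the scatter); compound 2 gives a higher number than compound 1, and that gap lies beyond the scatter.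

Compound 4, `CCCCC[C@@H](CCC[C@@H]1CC=CC(=O)O1)OC`, is the unmeasured member. Against compound 1 the change is the two compounds have the same atoms and bonds and differ only in configuration as drawn: 1 of 2 stereo elements differ; a stereocentre at a saturated ring carbon is drawn S in compound 1 and R in compound 4. For the measured compounds named here, the only measured step that bears on a change of configuration is a 1.6-fold lower number from compound 2 to compound 3 (0.21 log units; within the scatter), which is a pure stereochemical comparison because of the fact that compounds 2 and 3 differ only in the configuration as drawn; it involved the same ring stereocentre together with one chain stereocentre and stayed within the scatter. On that basis no step beyond the scatter is expected from compound 1 to compound 4 in this assay, and the estimated step is a 1.2-fold higher number from compound 1 to compound 4 (0.08 log units; within the scatter). Compound 4 is therefore expected to give about 25000 nM in this assay, within an expected range of 12000 nM to 50000 nM.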

Compound 4, half-maximal inhibitory concentration: 14900 nM
For compound 4 the middle estimate is 1.7-fold (0.22 log units) above the measured one; the measured number falls inside the stated range.
By their numbers in this assay, from the lowest: compounds 4, 1, 3 and 2 (each within the scatter of the next, the first and the last beyond it).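

In this assay, changing the saturated ring carbon stereocentre from S to R, with nothing else altered, gives a 1.4-fold lower number from compound 1 to compound 4 (0.14 log units; within the scatter). For the compounds shown here, the earlier pair, compounds 2 and 3, changed this stereocentre only together with a chain stereocentre, so this is the first reading of the ring stereocentre alone, and it also stays within the scatter. The step can be read as one of configuration at this single position because no other feature separates the pair: the fact that compounds 1 and 4 differ only in the configuration as drawn

As far as these compounds go, the effect of the chain stereocentre on its own remains open, as does the effect of the ring stereocentre alone in the hydroxy compounds. Also open, from the compounds shown here alone, is whether an amine or a carboxylic acid in place of the hydroxy, or a longer chain, would give a step beyond the scatter.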